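The compounds below may be only part of what the source reports. "The series", "measured", "known", "first", "only" and "open" are said of these compounds alone.

Compound 1 `O=C(Nc1ccc(Oc2ccnc3[nH]ccc23)cc1)c1nn(-c2ccc(Cl)cc2)ccc1=O` gives 10600 nM in a functional assay on MCF7 cells (Homo sapiens) for cytotoxicity, read by MTT assay, with a stated time of 72 h (a higher number here means a weaker inhibitor, a lower number a stronger inhibitor), the higher of the two numbers in this set. Compound 2 `O=C(Nc1ccc(Oc2ccnc3[nH]ccc23)cc1)c1nn(-c2ccc(Cl)c(C(F)(F)F)c2)ccc1=O` gives 6270 nM, and the change from compound 1 to compound 2 is a 1.7-fold lower number from compound 1 to compound 2 (0.23 log units; within the scatter). Compound 3 `O=C(Nc1ccc(Oc2ccnc3[nH]ccc23)c(F)c1)c1nn(-c2ccc(Cl)cc2)ccc1=O` gives only a limit of the assay, > 60000 nM, so (the limit of > 60000 nM in this assay, at which 1 of the 3 values shown sits). The step from compound 1 to compound 3 is an at least 5.6-fold higher number from compound 1 to compound 3 (0.75 log units; beyond the scatter).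

Compound 4 `Cn1ccc2c(Oc3ccc(NC(=O)c4nn(-c5ccc(Cl)cc5)ccc4=O)cc3)ccnc21` differs from compound 1 by methyl in place of hydrogen on an aromatic nitrogen. Neither measured step touches an aromatic nitrogen; both alter aromatic carbons elsewhere, so they bear on this change only loosely. Compound 4 is therefore expected to give 12000 nM, in the range 4000 nM to 40000 nM, a step of a 1.1-fold higher number from compound 1 to compound 4 (0.05 log units; within the scatter) that is expected to stay within the scatter.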

Compound 4, half-maximal inhibitory concentration: > 60000 nM
Compound 4 was reported as a limit; the forecaster's own chance of this, stated with the estimate: 15%; middle value at least 5.0-fold (0.69 log units) from the limit.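

In this assay, methyl in place of hydrogen on the aromatic nitrogen of the five-membered ring gives an at least 5.6-fold higher number from compound 1 to compound 4 (0.75 log units; beyond the scatter), a loss beyond the scatter from a change of a single heavy atom. This is the first change shown at this nitrogen, and it places compound 4 with compound 3, the only other compound reported as a limit of the assay: the limit of > 60000 nM in this assay, at which 2 of the 4 values shown sit.

The size of the loss therefore stays unresolved. The compounds shown carry only hydrogen or methyl on this nitrogen, so it remains open whether an ethyl group, a longer chain or a chain ending in an amine would give the same result.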